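The compounds below may be only part of what the source reports. "The series", "measured", "known", "first", "only" and "open" are said of these compounds alone.

Going by the values given here, in a functional assay on HepG2 cells (Homo sapiens) for antiproliferative activity, read by MTT assay, with a stated time of 72 h (on this read-out higher numbers stand for weaker inhibition and lower numbers for stronger inhibition), only two related compounds have readings so far. Among the compounds with values here, compound 1 `COc1ncc(-c2ccc3c(c2)NC(=O)CO3)cc1NS(=O)(=O)c1ccc(F)cc1` gives a measured value of 6590 nM and serves as the one firm number in this small set. Compound 2 `COc1ccc(N2C(=O)COc3ccc(-c4cnc(Cl)c(NS(=O)(=O)c5ccc(F)cc5)c4)cc32)cc1` gives > 40000 nM in this assay and that reading is a limit, not a number. Compound 2 therefore stands at the limit of > 40000 nM in this assay, at which 1 of the 2 values shown sits, and offers no exact starting point.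

Compound 3 `O=C1COc2ccc(-c3cnc(Cl)c(NS(=O)(=O)c4ccc(F)cc4)c3)cc2N1c1ccc(Cl)cc1` keeps the rest of compound 2 and alters a single group: chloro in place of methoxy on an aromatic carbon. In words, chloro takes the place of methoxy on an aromatic carbon, so 4-methoxyphenyl becomes 4-chlorophenyl. Within the data shown here, no pair of measured compounds shows what this swap does, so any forecast is cautious. In this assay no change beyond the usual scatter is expected, and no direction can be favoured. The estimated change a number no higher from compound 2 to compound 3 (the limit leaves the size open) is accordingly expected to be small, and a second limit reading would be no surprise. For compound 3 the expected half-maximal inhibitory concentration is 40000 nM, with an estimated range from 18000 nM to 90000 nM.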

Compound 3, half-maximal inhibitory concentration: 33900 nM
Beside the measured number, compound 3's estimate is 1.2-fold (0.07 log units) above it; the measured number falls inside the stated range.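

In this assay compound 3, which carries 4-chlorophenyl at this position, gives 33900 nM, so this position now has an exact number to work from. Compound 2, with 4-methoxyphenyl at the same position, gives only a limit and not a number: the limit of > 40000 nM in this assay, at which 1 of the 3 values shown sits.

As far as these compounds go, putting chloro in place of methoxy on the aromatic carbon gives an at least 1.1-fold lower number from compound 2 to compound 3 (0.07 log units; that floor lies within the scatter), so this change can be read only as a floor, and the true distance between the two compounds remains unknown.

The compounds shown leave open whether a different group on that aromatic carbon, such as an amine or a carboxylic acid, would give a clearly lower or higher number in this assay. Compound 1 differs from compound 3 in more than one place, so these compounds also cannot show how much each of those differences contributes on its own.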